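The source may report more compounds than this note shows. Statements on the series, on what has been measured and on what is new or still open speak of the compounds shown alone.

Three compounds that share one core and differ in a single group on an aromatic carbon have been measured in a toxicity assay on CCRF-CEM cells (Homo sapiens) for cytotoxicity; on this read-out higher numbers stand for lower toxicity in this test and lower numbers for higher toxicity in this test. Compound 1 `Cc1cccc2c1nc(-c1c(F)cccc1F)n2Cc1c(F)cccc1F`, which carries methyl there, gives > 100 uM, and this is a limit of the assay and not a number. Compound 2 `COc1cccc2c1nc(-c1c(F)cccc1F)n2Cc1c(F)cccc1F`, with methoxy, gives 44.3 uM, and compound 3 `CC(=O)Nc1cccc2c1nc(-c1c(F)cccc1F)n2Cc1c(F)cccc1F`, with acetamido, gives 39.3 uM. Within the data shown here, these are the only two true numbers so far, and they lie within the scatter of each other.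

Compound 4 `NC(=O)c1cccc2c1nc(-c1c(F)cccc1F)n2Cc1c(F)cccc1F` is still unmeasured. It carries carbamoyl in place of acetamido on an aromatic carbon.

Among the measured compounds shown here, no measured step introduces carbamoyl, so the guidance is indirect. Replacing methyl gave an at least 2.2-fold lower number from compound 1 to compound 2 (0.35 log units; beyond the scatter) with methoxy and an at least 2.5-fold lower number from compound 1 to compound 3 (0.40 log units; beyond the scatter) with acetamido. Both are beyond the scatter, though both start from the limit. The closest guide is the step that swaps one of these larger groups for another, a 1.1-fold lower number from compound 2 to compound 3 (0.05 log units; within the scatter), which stays within the scatter. On that basis, no step beyond the scatter is expected in this assay for the new swap. The expected change is a 1.3-fold higher number from compound 3 to compound 4 (0.10 log units; within the scatter). The estimate for compound 4 is 50 uM, with an expected range of 22 uM to 100 uM.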

Compound 4, half-maximal toxic concentration: > 100 uM
Compound 4 gave a limit, no number; the forecaster's own chance of this, stated with the estimate: 25%; middle value at least 2.0-fold (0.30 log units) away from the limit.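

The position is sensitive to the group it carries, and a small change in that group can matter: in this assay, carbamoyl in place of acetamido gives an at least 2.5-fold higher number from compound 3 to compound 4 (0.40 log units; beyond the scatter), and carbamoyl in place of methoxy gives an at least 2.2-fold higher number from compound 2 to compound 4 (0.35 log units; beyond the scatter). Higher numbers here mean lower toxicity in this test, so both steps point that way, and the close agreement of compound 2 and compound 3 does not extend to every group other than methyl, since carbamoyl departs from it even though it has the same counted hydrogen-bond donors and acceptors as acetamido and differs from it by a single carbon. Compound 4 gives a limit and not a number, as does compound 1: the limit of > 100 uM in this assay, at which 2 of the 4 values shown sit.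

The step between compound 1 and compound 4 cannot be read, so these two groups cannot be ranked against each other. From the compounds shown here alone, it also remains open whether an amine, a carboxylic acid or a longer amide chain on this aromatic carbon would stay at the limit or give a true number in this assay.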